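A few compounds are considered here, and "the series" means these few. Any claim that something is new, unique, unknown or untested is made for them only; others in the source may bear on it.

In a functional assay on M14 cells (Homo sapiens) for cytotoxicity (a higher number here means a weaker inhibitor of growth, a lower number a stronger inhibitor of growth), compound 1 (`COc1ccc(C2=C(c3ccc(SC)cc3)CC3CCCN3C2=O)cc1C`) gives 200 nM and compound 2 (`CSc1ccc(C2=C(c3ccc(F)c(F)c3)C(=O)N3CCCC3C2)cc1`) gives 300 nM, while compound 3 (`COc1ccc(C2=C(c3ccc(SC)cc3)CC3CCCN3C2=O)cc1`) gives 4000 nM as the weakest of the three. Compound 4 (`CSc1ccc(C2=C(c3ccc(O)cc3)C(=O)N3CCCC3C2)cc1`) differs from compound 3 in one place (hydrogen in place of methyl on an oxygen on an aromatic ring), which turns 4-methoxyphenyl into 4-hydroxyphenyl. Among the compounds with values here, no measured pair makes this swap. The nearest evidence concerns the same group: removing a methyl gave a 20-fold higher number from compound 1 to compound 3 (1.30 log units; beyond the scatter) and replacing 3,4-difluorophenyl by 4-methoxyphenyl gave a 13-fold higher number from compound 2 to compound 3 (1.12 log units; beyond the scatter) as the change. These large steps show that changes there can count, but neither gives a direction for methoxy to hydroxy. Only a small shift toward a lower number is therefore expected (a 1.3-fold lower number from compound 3 to compound 4 (0.12 log units; within the scatter)), probably within the scatter. Compound 4 is estimated at 3000 nM with 700 nM to 12000 nM as the expected range.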

Compound 4, concentration for 50% growth inhibition: > 100000 nM
Compound 4: a limit, no number; the forecaster's own chance of this, stated with the estimate: 10%; middle value at least 33-fold (1.52 log units) from the limit.
By their numbers in this assay, from the lowest: compounds 1 and 2 (each within the scatter of the next); then compound 3. At a limit, above all of these: compound 4.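

Compound 4 stands at a limit of the assay, not at a number: the limit of > 100000 nM in this assay, at which 1 of the 4 values shown sits. Within the data shown here, the earlier compounds showed only that this group can count, whereas replacing methoxy with hydroxy now gives a direction, with an at least 25-fold higher number from compound 3 to compound 4 (1.39 log units; beyond the scatter). The 4-hydroxyphenyl group also compares poorly with the other groups at this place, with an at least 330-fold higher number from compound 2 to compound 4 (2.52 log units; beyond the scatter) and an at least 500-fold higher number from compound 1 to compound 4 (2.69 log units; beyond the scatter).

The compounds shown leave open how far the true value of compound 4 lies past its limit. They also leave open whether an amine here would behave like hydroxy, or a longer chain on the oxygen, such as ethoxy, like methoxy.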